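Unsaturation in a Short Acyl Chain on the Shared Core

This account rests on a few compounds, and the source may have more. Where it says the series, first, only, none or still open, it means among the compounds named here.

Compound 1 `CC(C)CCC(=O)Nc1ccn([C@H]2CC[C@H](O)[C@@H](C)O2)c(=O)n1` carries an isopentyl group on the carbonyl carbon of its amide. In a functional assay on HCT-116 cells (Homo sapiens) for cytotoxicity, read by sulforhodamine B assay, with a stated time of 24 h (on this read-out higher numbers stand for weaker inhibition and lower numbers for stronger inhibition), compound 1 gives only a limit, > 20000 nM, not a number. Two related compounds, which differ from compound 1 elsewhere in their structures, do give numbers. Compound 2 `C/C=C(\C)C(=O)Nc1ccn([C@H]2CC[C@H](O[C@H]3O[C@H](C)[C@@H](N(C)C)[C@H](O)[C@H]3O)[C@@H](C)O2)c(=O)n1` gives 6450 nM, and compound 3 `CC(C)C(=O)Nc1ccc(C(=O)Nc2ccn([C@H]3CC[C@H](O[C@H]4O[C@H](C)[C@@H](N(C)C)[C@H](O)[C@H]4O)[C@@H](C)O3)c(=O)n2)cc1` gives 6630 nM. The change a 1.0-fold higher number from compound 2 to compound 3 (0.01 log units; within the scatter) shows that swapping one acyl group for a quite different one left this assay essentially unchanged.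

Compound 4 `CC(C)/C=C/C(=O)Nc1ccn([C@H]2CC[C@H](O)[C@@H](C)O2)c(=O)n1` is compound 1 with a double bond introduced into the acyl chain: 3-methylbut-1-en-1-yl in place of isopentyl on a carbonyl carbon. Within the data shown here, no measured step covers exactly this change. Among the measured compounds shown here, the only step in hand, a 1.0-fold higher number from compound 2 to compound 3 (0.01 log units; within the scatter), suggests that the acyl group can be varied with little effect on this assay, but it sits on a different pair of compounds. Compound 1 itself sits at the limit of > 20000 nM in this assay, at which 1 of the 3 values shown sits, so there is no number to move from. Compound 4 is therefore expected to stay weak, with the step that the limit leaves unreadable from compound 1 to compound 4 estimated as small. The estimate for compound 4 is 25000 nM, within a range of 8000 nM to 80000 nM.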

Compound 4, half-maximal inhibitory concentration: > 20000 nM
Compound 4 was reported as a limit; the forecaster's own chance of this, stated with the estimate: 65%; the middle value lies beyond the limit too.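

Compound 1 and compound 4 are both reported in this assay only as limits, not as numbers, so no step between them can be read: the limit of > 20000 nM in this assay, at which 2 of the 4 values shown sit.

Going by these compounds, whether 3-methylbut-1-en-1-yl in place of isopentyl on the carbonyl carbon changes the result in this assay at all stays open.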